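Extending an Inactive Compound With a 3-Hydroxypropyl Chain

The source may report more compounds than this note shows. Statements on the series, on what has been measured and on what is new or still open speak of the compounds shown alone.

Compound 1, `CC(C)(C)[Si](C)(C)O[C@@H]1CCCO[C@@H]1CO`, carries a protected alcohol on a saturated ring and a free hydroxymethyl group. In a functional assay on A2780 cells (Homo sapiens) for antiproliferative activity, read by sulforhodamine B assay, with a stated time of 48 h (a lower number here means a stronger inhibitor of growth, a higher number a weaker inhibitor of growth), compound 1 reaches only a limit of the assay, > 100000 nM, not a number. Compound 2, `O=C(COC[C@H]1OCCC[C@@H]1O)OCc1ccccc1`, likewise gives only a limit of > 100000 nM in this assay. Both measured values share one feature: the limit of > 100000 nM in this assay, at which 2 of the 2 values shown sit. Compound 3, `CC(C)(C)[Si](C)(C)O[C@@H]1CCCO[C@@H]1COCCCO`, differs from compound 1 by 3-hydroxypropyl in place of hydrogen on an oxygen on a saturated carbon. With both known compounds at the limit, the expected step from compound 1 to compound 3 is none beyond the scatter, estimated as a number no higher from compound 1 to compound 3 (the limit leaves the size open). Compound 3 is therefore expected to give about 100000 nM, most likely between 30000 nM and 300000 nM, and probably again only a limit.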

Compound 3, concentration for 50% growth inhibition: > 100000 nM
Compound 3: a limit, no number (the forecaster's own chance of this, stated with the estimate: 85%); the middle value lies on the limit itself.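

Among these compounds, no step from compound 1 to compound 3 can be read, because both give only a limit and not a number: the limit of > 100000 nM in this assay, at which 3 of the 3 values shown sit. The compounds shown leave open each one's true value, and whether 3-hydroxypropyl changes it at all.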